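A few compounds are considered here, and "the series" means these few. Any claim that something is new, unique, unknown or untested is made for them only; others in the source may bear on it.

Of the compounds shown here, three sharing one core have been tested in a functional assay on MKN-45 cells (Homo sapiens) for cytotoxicity, read by MTT assay, with a stated time of 48 h; on this read-out higher numbers stand for weaker inhibition and lower numbers for stronger inhibition. Compound 1 `CCc1nnc(SCC(=O)c2ccccc2)n1N1C(=O)c2ccccc2C1=O` gives > 200000 nM, which is a limit of the assay rather than a number. Compound 2 `C=CCSc1nnc(-c2cc(OC)c(OC)c(OC)c2)n1N1C(=O)c2ccccc2C1=O` likewise reaches only the limit > 200000 nM. Compound 3 `COc1cc(-c2nnc(SC)n2N2C(=O)c3ccccc3C2=O)cc(OC)c1OC` also stops at the limit > 200000 nM. The step that the two limits leave unreadable from compound 2 to compound 3 therefore cannot be read, as the limit of > 200000 nM in this assay, at which 3 of the 3 values shown sit, records. Compound 4 `COc1cc(-c2nnc(SCC(=O)c3ccccc3)n2N2C(=O)c3ccccc3C2=O)cc(OC)c1OC` differs from compound 3 by benzoyl in place of hydrogen on a saturated chain carbon bound to a sulfur. Compound 1 already carries this (benzoylmethyl)sulfanyl group and sits at the limit, so the expected step that the limit leaves unreadable from compound 3 to compound 4 is none beyond the scatter. Compound 4 is expected to give 300000 nM in this assay, within a range from 100000 nM to 1000000 nM, most likely again only as a limit.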

Compound 4, half-maximal inhibitory concentration: > 200000 nM
Compound 4: a limit, no number; the forecaster's own chance of this, stated with the estimate: 85%; the middle value lies beyond the limit too.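

Compound 4 stops at a limit, as do compound 1, compound 2 and compound 3, so no step among these four can be read: the limit of > 200000 nM in this assay, at which 4 of the 4 values shown sit.

The compounds shown leave open which change to the shared core, if any, would give a readable number.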